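The source may hold more compounds than are shown below. What is called first, only, known or untested is meant among the compounds shown, and "the series" means these compounds.

Going by the values given here, in a functional assay on HepG2 cells (Homo sapiens) for inhibition, read by MTT assay, with a stated time of 72 h, tested at 50 uM (a higher number here means more inhibition of growth at the concentration tested, a lower number less inhibition of growth), compound 1 `C=CCc1cc(O)c(O)c(CN2CCC(C)CC2)c1` gives 69.7%, the higher of the two numbers measured so far. Compound 2 `C=CCc1ccc(OCc2cn(-c3cc(OC)c(OC)c(OC)c3)nn2)c(O)c1` gives 2.5%, and this gap lies well beyond the usual scatter of repeated measurements. However, the two structures differ in more than one place, so their gap cannot be tied to any single group.

The next compound, compound 3 `C=CCc1cc(O)c(O)c(CN2CCC(Cc3ccccc3)CC2)c1`, keeps the core of compound 1 and differs from it in one place: phenyl in place of hydrogen on a saturated chain carbon bound to a saturated ring carbon. Put another way, the methyl of compound 1 becomes a benzyl. Among the compounds with values here, no measured pair shows what this change does, which leaves compound 1, at 69.7%, as the only starting point. With no evidence for either direction, no step beyond the scatter is expected in this assay. The estimated change is a number 2.3 percentage points higher from compound 1 to compound 3 (within the scatter), although a wide range must be allowed. For compound 3 the expected value is 72%, with an estimated range from 45% to 95%.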

Compound 3, percent growth inhibition at one concentration: 84%
Compound 3: the middle estimate sits 12 percentage points below what was measured; measured number inside the range.
By their numbers in this assay, from the lowest: compound 2; then compound 1; then compound 3.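

In this assay, turning the methyl into a benzyl gives a number 14.3 percentage points higher from compound 1 to compound 3 (beyond the scatter). Going by these compounds alone, this is the first change in a single place that can be read, and it shows that a phenyl on a saturated chain carbon bound to a saturated ring carbon, adding six carbon atoms in one aromatic ring, does not cost growth inhibition on this core and instead raises it by a modest step. Nothing measured here accounts for this rise, so the step stands as an observation without an explanation.

A single pair cannot show whether the gain belongs to the aromatic ring itself or would come with any larger group at this place, and a cyclohexyl in place of the phenyl, or a phenyl carrying a chlorine atom or a methoxy group, would begin to separate these readings. From the compounds shown here alone, it also remains open how the compounds compare across a range of concentrations, since each number here is a reading at one concentration only.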